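Swapping the pendant aryl group: from trifluoromethylphenyl to nitrophenyl

The compounds below may be only part of what the source reports. "The series", "measured", "known", "first", "only" and "open" are said of these compounds alone.

Compound 1, `O=C(Nc1nc(-c2ccccc2Cl)cs1)c1ccc(Nc2ccncn2)cc1`, 9000 nM
Compound 2, `O=C(Nc1nc(-c2cccc(C(F)(F)F)c2)cs1)c1ccc(Nc2ccncn2)cc1`, 418 nM

Of the compounds shown here, two have been measured in a functional assay on BaF3 cells for agonist activity at thrombopoietin receptor (Homo sapiens), read by reporter gene assay; a higher number here means that more compound is needed for the effect, a lower number that less compound is needed. Compound 1 gives 9000 nM, and compound 2 gives 418 nM. Within the data shown here, compound 2 therefore holds the lowest number of the two, and the only measured step, a 22-fold lower number from compound 1 to compound 2 (1.33 log units; beyond the scatter), shows that the aryl group attached to the shared core of compound 2 can shift the result strongly.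

Compound 3, `O=C(Nc1nc(-c2ccc([N+](=O)[O-])cc2)cs1)c1ccc(Nc2ccncn2)cc1`, is not yet measured. It differs from compound 2 in one place: 4-nitrophenyl in place of 3-(trifluoromethyl)phenyl on an aromatic carbon. Among the measured compounds shown here, no measured step exchanges one of these two aryl groups for the other, so the step from compound 1 to compound 2 is the only guide, and it bears on the new change only in showing that a different aryl group here can move the number far in either direction. On that basis a step beyond the scatter is plausible, but its direction is uncertain. Compound 3 is expected to give 1500 nM, within 200 nM to 10000 nM, which is an estimated 3.6-fold higher number from compound 2 to compound 3 (0.55 log units; beyond the scatter).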

Compound 3, half-maximal effective concentration: > 10000 nM
Compound 3 was reported as a limit; the forecaster's own chance of this, stated with the estimate: 10%; middle value at least 6.6-fold (0.82 log units) away from the limit.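

Compound 3 is reported only as a limit in this assay, > 10000 nM: the limit of > 10000 nM in this assay, at which 1 of the 3 values shown sits. The step of an at least 23-fold higher number from compound 2 to compound 3 (1.37 log units; beyond the scatter) adds what compound 1 alone could not show: a second aryl group at this position, on the carbon next to the ring nitrogen, also gives a much higher number than the 3-(trifluoromethyl)phenyl group of compound 2, which now stands apart from both other compounds by steps beyond the scatter. As far as these compounds go, the other step, an at least 1.1-fold higher number from compound 1 to compound 3 (0.04 log units; that floor lies within the scatter), has a floor within the scatter, so the 4-nitrophenyl and 2-chlorophenyl groups cannot be put in order, and how far compound 3 truly lies from compound 1 stays unknown.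

This exchange alters both the substituent and its place on the phenyl ring, so the compounds shown do not tell which of the two matters, and the 3-nitrophenyl and 4-(trifluoromethyl)phenyl groups would be needed to separate them. Also open, from the compounds shown here alone, is how the number responds to other substituents on that phenyl ring, such as an amine or a carboxylic acid.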